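A few compounds are considered here, and "the series" means these few. Any claim that something is new, unique, unknown or untested is made for them only; others in the source may bear on it.

Measured so far:
- compound 1 `O=C(NCc1ccc(F)cc1)c1cc(Oc2ccc(/C=C/c3ccccn3)cc2)ccn1` — in a functional assay on A549 cells (Homo sapiens) for antiproliferative activity, read by CCK-8 assay, with a stated time of 48 h (on this read-out higher numbers stand for weaker inhibition and lower numbers for stronger inhibition), compound 1 gives > 100000 nM, which is a limit of the assay rather than a number.
- compound 2 `O=C(Nc1ccc(Cl)cc1)c1cc(Oc2ccc(/C=C/c3ccncc3)cc2)ccn1` — compound 2 gives 62100 nM.
- compound 3 `O=C(NCc1ccccc1)c1cc(Oc2ccc(/C=C/c3ccncc3)cc2)ccn1` — compound 3 gives 17000 nM.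

Among the two numbers shown, compound 3 stands at the lowest; its nearest neighbour is compound 2, and the step of a 3.7-fold lower number from compound 2 to compound 3 (0.56 log units; beyond the scatter) is the only measured step between compounds that differ in one place. The limit at which compound 1 sits is described by the limit of > 100000 nM in this assay, at which 1 of the 3 values shown sits.

Compound 4 `O=C(NCc1ccc(F)cc1)c1cc(Oc2ccc(/C=C/c3ccncc3)cc2)ccn1` is not yet measured. It differs from compound 3 by fluoro in place of hydrogen on an aromatic carbon. Within the data shown here, no measured step touches a fluoro group on this ring, so the one step known, from a 4-chlorophenyl to a benzyl group on the amide-type nitrogen, does not bear directly on this change. A step of no size beyond the scatter is therefore expected: for compound 4 the estimated step of a 1.2-fold higher number from compound 3 to compound 4 (0.07 log units; within the scatter) is small. Compound 4 is expected to give about 20000 nM, within a range from 7000 nM to 60000 nM.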

Compound 4, half-maximal inhibitory concentration: 18200 nM
The estimate for compound 4 lay 1.1-fold (0.04 log units) above the measured number, within the range that was stated.
By their numbers in this assay, from the lowest: compounds 3 and 4 (each within the scatter of the next); then compound 2. At a limit, above all of these: compound 1.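

In this assay, fluoro in place of hydrogen on the aromatic carbon para to a large group gives no step beyond the scatter: a 1.1-fold higher number from compound 3 to compound 4 (0.03 log units; within the scatter). The 4-fluorobenzyl group also stays clear of the 4-chlorophenyl group on the amide-type nitrogen, as the plain benzyl group did: a 3.4-fold lower number from compound 2 to compound 4 (0.53 log units; beyond the scatter). With the 4-fluorobenzyl group held in place, pyridin-4-yl in place of pyridin-2-yl on the double-bonded chain carbon gives an at least 5.4-fold lower number from compound 1 to compound 4 (0.73 log units; beyond the scatter); the starting point of that step is a limit of the assay and not a number: the limit of > 100000 nM in this assay, at which 1 of the 4 values shown sits.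

From the compounds shown here alone, whether chloro, methoxy or an amine at the same ring carbon would also leave the number within the scatter stays open. So does the place of pyridin-3-yl on the double-bonded chain, which would show how the pyridine nitrogen's position ranks beyond these two cases.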